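A Second Methoxy on the Benzyloxy Arm

The compounds below may be only part of what the source reports. "The series", "measured", "known", "first", "only" and "open" are said of these compounds alone.

Compound 3 `COc1cccc(COc2ccc(-c3cc(CN4CCN(Cc5ccc(C(F)(F)F)cc5)CC4)no3)cc2)c1` stands second highest of the three numbers in a functional assay on MCF7 cells (Homo sapiens) for antiproliferative activity, read by sulforhodamine B assay, with a stated time of 72 h (a lower number here means a stronger inhibitor, a higher number a weaker inhibitor), where compound 3 gives 2000 nM. Compound 1 `Fc1cccc(COc2ccc(-c3cc(CN4CCN(Cc5ccc(C(F)(F)F)cc5)CC4)no3)cc2)c1` gives 2500 nM and lies nearest, with a 1.3-fold lower number from compound 1 to compound 3 (0.10 log units; within the scatter). Compound 2 `COc1ccccc1COc1ccc(-c2cc(CN3CCN(Cc4ccc(C(F)(F)F)cc4)CC3)no2)cc1` gives 300 nM, the lowest of the three, with a 6.7-fold higher number from compound 2 to compound 3 (0.82 log units; beyond the scatter). Compound 4 `COc1cc(COc2ccc(-c3cc(CN4CCN(Cc5ccc(C(F)(F)F)cc5)CC4)no3)cc2)cc(OC)c1` carries methoxy in place of hydrogen on an aromatic carbon. For the measured compounds named here, no measured step adds a group of this kind; the closest precedent is a 1.3-fold lower number from compound 1 to compound 3 (0.10 log units; within the scatter), which shows a methoxy in place of a fluoro barely moving the number, while an 8.3-fold lower number from compound 1 to compound 2 (0.92 log units; beyond the scatter) shows that where the methoxy sits matters more than its presence. A step within the scatter is therefore expected, no change at the digits printed from compound 3 to compound 4 (within the scatter), and compound 4 is estimated at 2000 nM with a range of 800 nM to 5000 nM.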

Compound 4, half-maximal inhibitory concentration: 100 nM
Estimate against measurement, compound 4: 20-fold (1.30 log units) above, outside the stated range (below it).
By their numbers in this assay, from the lowest: compound 4; then compound 2; then compounds 3 and 1 (each within the scatter of the next).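

In this assay, adding a methoxy in place of hydrogen on an aromatic carbon, meta to a methoxy group, gives a 20-fold lower number from compound 3 to compound 4 (1.30 log units; beyond the scatter), so this ring responds strongly to a second methoxy, whereas methoxy in place of fluoro had stayed within the scatter. The 3,5-dimethoxyphenyl arm also outdoes the best single-methoxy arm, with a 3.0-fold lower number from compound 2 to compound 4 (0.48 log units; beyond the scatter), and the fluoro arm, with a 25-fold lower number from compound 1 to compound 4 (1.40 log units; beyond the scatter). Nothing available here accounts for this gain. From the compounds shown here alone, whether an ethoxy, a hydroxy or an amino group on that aromatic carbon would give the same gain stays open.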